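Shortening the Ether: Cyclopentyloxy to Methoxy

A few compounds are considered here, and "the series" means these few. Any claim that something is new, unique, unknown or untested is made for them only; others in the source may bear on it.

Three amides built on one shared core have been measured in an assay for inhibition of Polyunsaturated fatty acid 5-lipoxygenase (Homo sapiens), read by spectrophotometry, tested at 20 uM; a higher number here means more inhibition at the concentration tested (going by the name of the read-out), a lower number less inhibition. Compound 1 `O=C(/C=C/C=C/c1ccc(Cl)cc1)N1CCCCC1` gives 14.5%, compound 2 `COc1ccc(/C=C/C=C/C=C/C(=O)N2CCCCC2)cc1` gives 1.08%, and compound 3 `O=C(/C=C/C=C/c1ccc(OC2CCCC2)cc1)N1CCCCC1` gives 16.1%. Compound 3 has the highest of the three numbers, but its gap to compound 1 is within the scatter, so the two cannot be told apart; only compound 2 stands clearly lower. For the measured compounds named here, the single measured step, a number 1.6 percentage points higher from compound 1 to compound 3 (within the scatter), shows that exchanging the group on the aromatic ring changed little.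

Compound 4 `COc1ccc(/C=C/C=C/C(=O)N2CCCCC2)cc1` is compound 3 with methyl in place of cyclopentyl on an oxygen on an aromatic ring. Going by the values given here, no measured step covers this exact exchange. Compound 2 carries the same methoxy group and sits far lower, yet it also has a longer chain, so its number cannot be read as the effect of the methyl alone. Since the step from compound 1 to compound 3 lay within the scatter, a similarly small step is expected here, namely a number 6.1 percentage points lower from compound 3 to compound 4 (within the scatter). Compound 4 is estimated at 10%, between 0% and 22%.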

Compound 4, a percentage reported as inhibition, at one concentration (the size of the read-out at that concentration, not a potency): 42.6%
Beside the measured number, compound 4's estimate is 32.6 percentage points below it, and the stated range ends below it.
By their numbers in this assay, from the lowest: compound 2; then compounds 1 and 3 (each within the scatter of the next); then compound 4.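

Methyl in place of cyclopentyl on the oxygen gives a number 26.5 percentage points higher from compound 3 to compound 4 (beyond the scatter) in this assay, so what stands on this oxygen clearly counts. Methoxy in place of chloro on the same aromatic carbon gives a number 28.1 percentage points higher from compound 1 to compound 4 (beyond the scatter), which shows that this position is far from indifferent, although the earlier exchange of chloro for cyclopentyloxy gave only a number 1.6 percentage points higher from compound 1 to compound 3 (within the scatter). An oxygen at this place is not enough on its own: compound 3 carries one too, yet it cannot be told apart from compound 1.

Nothing shown here explains why methoxy stands apart from the other two groups. Going by these compounds, whether ethoxy, with a chain one carbon longer, would stay close to methoxy or fall back towards cyclopentyloxy remains open, as does the outcome with a hydroxyl or an amine at this place.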